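The source may hold more compounds than are shown below. What is called first, only, known or untested is meant among the compounds shown, and "the series" means these compounds.

Measured so far:
Compound 1 `O=S(=O)(Nc1ccc2oc(-c3ccccc3)nc2c1)c1ccc(Cl)c(C(F)(F)F)c1`: in an assay on cells for inhibition of HSP60/HSP10 (Homo sapiens), with a stated time of 60 min (on this read-out lower numbers stand for stronger inhibition and higher numbers for weaker inhibition), compound 1 reaches only the assay limit, > 100000 nM.
Compound 2 `CS(=O)(=O)Nc1ccc2oc(-c3ccccc3)nc2c1`: in this assay compound 2 likewise gives only a limit, > 100000 nM.
Compound 3 `O=S(=O)(Nc1ccc(-c2nc3ccccc3o2)cc1)c1cccc(F)c1`: in this assay compound 3 gives 71000 nM.

Compound 2 thus stands at a limit rather than a number, shared with compound 1 (the limit of > 100000 nM in this assay, at which 2 of the 3 values shown sit), so the two cannot be ordered; only compound 3 carries a measured value, and that a weak one. Compound 4 `O=S(=O)(Nc1ccc2oc(-c3ccccc3)nc2c1)c1cccc(Cl)c1` differs from compound 2 by 3-chlorophenyl in place of methyl on a sulfonyl sulfur. Among the compounds with values here, no measured step covers this change. Compound 1, a sulfonamide on the same core, also sits at the limit, so no gain beyond the scatter is expected. Compound 4 is expected near 90000 nM (range 30000 nM to 300000 nM), a step of an at least 1.1-fold lower number from compound 2 to compound 4 (0.04 log units; that floor lies within the scatter) that may well remain at the limit.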

Compound 4, half-maximal inhibitory concentration: > 100000 nM
Compound 4 was reported as a limit; the forecaster's own chance of this, stated with the estimate: 50%; middle value at least 1.1-fold (0.04 log units) from the limit.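

Compound 2 and compound 4 both stand only as limits, so no step can be read between them: the limit of > 100000 nM in this assay, at which 3 of the 4 values shown sit. The compounds shown leave open whether any sulfonyl substituent on the shared core gives a measurable value on this read-out.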